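From amide to ether at the saturated ring carbon

The source may report more compounds than this note shows. Statements on the series, on what has been measured and on what is new or still open speak of the compounds shown alone.

Compound 2 `Cc1nn(-c2ncnc3nc[nH]c23)c2c1C(C(=O)N(C)c1nccs1)CC(=O)N2` is one of two compounds on a shared core examined in a functional assay on HEK293 cells for agonist activity at G-protein coupled receptor 39 (Homo sapiens), read by scintillation proximity assay and inositol phosphate accumulation, with a stated time of 75 min, in the presence of a further agent that is not named here; on this read-out lower numbers stand for an effect already at smaller amounts and higher numbers for an effect only at larger amounts of compound. In this assay compound 1 `Cc1nn(-c2ncnc3nc[nH]c23)c2c1C(C(=O)Nc1ccccc1)CC(=O)N2` gives 10 nM, and compound 2 gives 18 nM. For the measured compounds named here, the only measured step, a 1.8-fold higher number from compound 1 to compound 2 (0.26 log units; within the scatter), exchanges anilino for methyl(1,3-thiazol-2-yl)amino on a carbonyl carbon and stays within the scatter, so compound 2 and compound 1 are not set apart from each other by these two numbers.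

Compound 3 `Cc1nn(-c2ncnc3nc[nH]c23)c2c1C(OCc1ccccc1Cl)CC(=O)N2` differs from compound 2 in (2-chlorobenzyl)oxy in place of methyl(1,3-thiazol-2-yl)carbamoyl on a saturated ring carbon. Going by the values given here, this change removes the carbonyl carbon altogether, whereas the one measured step only varied the group attached to that carbon; that step therefore bears on the present change only weakly, and no measured compound carries an oxygen-linked group at this saturated ring carbon. For compound 3 the step expected in this assay is a 5.6-fold higher number from compound 2 to compound 3 (0.74 log units; beyond the scatter), held with wide uncertainty. The estimate for compound 3 in this assay is 100 nM, with a range from 10 nM to 1000 nM.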

Compound 3, half-maximal effective concentration: 2 nM
For compound 3 the middle estimate is 50-fold (1.70 log units) above the measured one; the measured number lies below the stated range.
By their numbers in this assay, from the lowest: compound 3; then compounds 1 and 2 (each within the scatter of the next).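

In this assay, the saturated ring carbon does not need a carbonyl carbon for a low number: putting (2-chlorobenzyl)oxy there in place of the methyl(1,3-thiazol-2-yl)carbamoyl group gives a clear drop (a 9.0-fold lower number from compound 2 to compound 3 (0.95 log units; beyond the scatter)), and the same holds against the phenylcarbamoyl group (a 5.0-fold lower number from compound 1 to compound 3 (0.70 log units; beyond the scatter)). The earlier step varied only what was attached to that carbonyl and left the two numbers within the scatter, whereas replacing the whole carbamoyl unit with this oxygen-linked group separates compound 3 from both amides. Nothing at hand explains why the number falls with this change.

Because the oxygen link, the benzyl carbon and the chlorine all enter together, these three compounds cannot show which of them accounts for the drop. From the compounds shown here alone, it remains open whether an unsubstituted benzyloxy group, a 2-chlorobenzylamino group with nitrogen as the link, or a longer chain such as 2-(2-chlorophenyl)ethoxy would keep the number of compound 3 at this ring carbon.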